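Swapping the 3,4-Dichlorophenyl Group of Compound 3 for Pyridine

This account rests on a few compounds, and the source may have more. Where it says the series, first, only, none or still open, it means among the compounds named here.

In a functional assay on A-375 cells (Homo sapiens) for activation, with a stated time of 3 days (a lower number here means that less compound is needed, a higher number that more compound is needed for the effect), compound 1 (`O=C(Nc1ccc(-c2cscn2)cc1)C1CCCN(Cc2ccc(F)cc2)C1`) gives 5000 nM, compound 2 (`O=C(Nc1ccc(-c2cscn2)cc1)C1CCCN(Cc2cccc(F)c2F)C1`) gives 10000 nM and compound 3 (`O=C(Nc1ccc(-c2cscn2)cc1)C1CCCN(Cc2ccc(Cl)c(Cl)c2)C1`) gives 3000 nM. Compound 3 thus stands within the scatter of compound 1, as a 1.7-fold lower number from compound 1 to compound 3 (0.22 log units; within the scatter) shows, and clearly apart from compound 2, as a 3.3-fold lower number from compound 2 to compound 3 (0.52 log units; beyond the scatter) shows. Compound 4 (`O=C(Nc1ccc(-c2cscn2)cc1)C1CCCN(Cc2cccnc2)C1`) carries pyridin-3-yl in place of 3,4-dichlorophenyl on a saturated chain carbon bound to an amine nitrogen in a ring. Going by the values given here, no measured step introduces a ring nitrogen, so the evidence is only indirect. The three measured changes to this group are small: a 2.0-fold higher number from compound 1 to compound 2 (0.30 log units; within the scatter) stays within the scatter, and a 3.3-fold lower number from compound 2 to compound 3 (0.52 log units; beyond the scatter) is the largest and only modest. A modest move towards a higher number is therefore expected, a 2.7-fold higher number from compound 3 to compound 4 (0.43 log units; beyond the scatter). The estimate for compound 4 is 8000 nM, with an expected range of 3000 nM to 20000 nM.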

Compound 4, half-maximal effective concentration: > 20000 nM
Compound 4: a limit, no number (the forecaster's own chance of this, stated with the estimate: 25%); middle value at least 2.5-fold (0.39 log units) from the limit.
By their numbers in this assay, from the lowest: compounds 3, 1 and 2 (each within the scatter of the next, the first and the last beyond it). At a limit, above all of these: compound 4.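

The value of compound 4 in this assay is a limit and not a number: the limit of > 20000 nM in this assay, at which 1 of the 4 values shown sits. Going by these compounds alone, the earlier compounds all carry a halogen-bearing phenyl group at this place, and compound 4, with pyridin-3-yl and no halogen, is the first to separate clearly from two of them, with an at least 6.6-fold higher number from compound 3 to compound 4 (0.82 log units; beyond the scatter) and an at least 4.0-fold higher number from compound 1 to compound 4 (0.60 log units; beyond the scatter). The third comparison stays unresolved, since an at least 2.0-fold higher number from compound 2 to compound 4 (0.30 log units; that floor lies within the scatter) gives only a floor, so compound 4 is not shown to differ from that compound.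

The compounds shown leave open whether the loss of the halogens or the arrival of the ring nitrogen matters here, since the two changes come together in compound 4. An unsubstituted phenyl group or a chloropyridinyl group at this place would separate them, and pyridin-4-yl would test where the nitrogen may stand.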